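Tert-butyl ester of the ring-fused acid: expected cell potency

The source may hold more compounds than are shown below. What is called first, only, known or untested is meant among the compounds shown, and "the series" means these compounds.

Compound 1 `CC1(C)[C@@H]2CC3=N[C@@H](CCC(=O)O)C(=O)O[C@@]3(C)[C@H]1C2` carries a free carboxylic acid on its side chain. In a functional assay on MCF7 cells (Homo sapiens) for antiproliferative activity, read by sulforhodamine B assay, with a stated time of 48 h (on this read-out lower numbers stand for stronger inhibition and higher numbers for weaker inhibition), compound 1 gives 38000 nM. Its mirror image, compound 2 `CC1(C)[C@H]2CC3=N[C@H](CCC(=O)O)C(=O)O[C@]3(C)[C@@H]1C2`, gives 34000 nM in this assay, so the two measured numbers stand together within the scatter and compound 1 is not set apart from compound 2 on this read-out. Among the compounds with values here, the only measured step, a 1.1-fold lower number from compound 1 to compound 2 (0.05 log units; within the scatter), rests on the fact that compounds 1 and 2 differ only in the configuration as drawn and does not touch the acid end of the side chain.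

Compound 3 `CC(C)(C)OC(=O)CC[C@@H]1N=C2C[C@@H]3C[C@@H](C3(C)C)[C@]2(C)OC1=O` differs from compound 1 by tert-butyl in place of hydrogen on an oxygen next to a carbonyl group. Within the data shown here, none of the measured steps involves this position, so no measured step bears on the change, and the size and direction of the step in this assay cannot be read from the data in hand. The estimate for compound 3 is therefore placed close to compound 1, with a wide range to either side. Compound 3 is expected to give 25000 nM in this assay, between 6000 nM and 80000 nM. This estimate means an expected step of a 1.5-fold lower number from compound 1 to compound 3 (0.18 log units; within the scatter).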

Compound 3, half-maximal inhibitory concentration: 40000 nM
For compound 3 the middle estimate is 1.6-fold (0.20 log units) below the measured one; low and high end bracket the measured number.
By their numbers in this assay, from the lowest: compounds 2, 1 and 3 (each within the scatter of the next).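

In this assay, tert-butyl in place of hydrogen on an oxygen next to a carbonyl group gives a 1.1-fold higher number from compound 1 to compound 3 (0.02 log units; within the scatter), so carboxy and tert-butoxycarbonyl are not told apart on this read-out. Within the data shown here, the earlier compounds left the end of the side chain untouched, and this is the first measured step at this place: in this one pair, the free carboxylic acid is not needed for a number of this size, and the added tert-butyl, with its 4 heavy atoms, leaves compounds 1 and 3 within the scatter of each other. Nothing in the data on hand bears on why this change leaves the two compounds together.

Still open, as far as these compounds go, is whether a methyl ester, a primary amide or a primary amine at the end of the side chain, or a longer chain carrying the same acid, would stay with compounds 1 and 3 or separate from them. Also open, from the compounds shown here alone, is whether the tert-butyl ester of compound 2 would stand with compound 2 as compound 3 stands with compound 1.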